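The source may hold more compounds than are shown below. What is called first, only, known or untested is meant among the compounds shown, and "the series" means these compounds.

On these data alone, the study sets two measured compounds beside one that is still untested, all read in a functional assay on P815 cells (Mus musculus) for antiproliferative activity; a higher number here means a weaker inhibitor, a lower number a stronger inhibitor. Within the data shown here, compound 1, `Cc1ccc(S(=O)(=O)O[C@@H]2[C@@H](O)[C@H](n3cc(F)c(N)nc3=O)O[C@@H]2CO)cc1`, is the only one with a full number: in this assay compound 1 gives 3.9 ug/mL. Compound 2, `Nc1nc(=O)n(C2OC(CO)C(Cl)C2O)cc1F`, shares the base of compound 1 but differs in the sugar part. For compound 2 this assay reports only a limit and no number, > 30 ug/mL. Compound 2 therefore stands at the limit of > 30 ug/mL in this assay, at which 1 of the 2 values shown sits, and how far beyond it the true value lies is not known.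

Compound 3, `Nc1ccn(C2OC(CO)C(Cl)C2O)c(=O)n1`, follows from compound 2 by one change, (hydrogen in place of fluoro on an aromatic carbon). Among the measured compounds shown here, no step between measured compounds is given, so there is nothing in the numbers to say how much a change on the base moves this assay. With the starting point itself only a limit, compound 3 is expected to remain close to it, and the step of a number no higher from compound 2 to compound 3 (the limit leaves the size open) is expected to be small, within the usual scatter or at most a modest gain. In this assay compound 3 is estimated at 30 ug/mL, ranging from 10 ug/mL to 100 ug/mL.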

Compound 3, concentration for 50% inhibition: > 100 ug/mL
Compound 3 ended at the assay's limit; the forecaster's own chance of this, stated with the estimate: 60%; middle value at least 3.3-fold (0.52 log units) away from the limit.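

In this assay compound 3 gives only a limit, > 100 ug/mL. Compound 2 likewise gives only a limit, > 30 ug/mL. With limits on both sides, no step can be read between compound 2 and compound 3. The compounds shown leave open how far hydrogen in place of fluoro on an aromatic carbon moves the activity.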